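Trimming the amine of a chlorinated biaryl benzylamine

A few compounds are considered here, and "the series" means these few. Any claim that something is new, unique, unknown or untested is made for them only; others in the source may bear on it.

In an assay on isolated protein for binding affinity to 5-hydroxytryptamine receptor 6 (Homo sapiens) (on this read-out lower numbers stand for stronger inhibition and higher numbers for weaker inhibition), compound 1 `CCCN(CCC)Cc1ccc(Cl)c(-c2ccccc2OC)c1` gives only a limit, > 10000 nM, rather than a number. As far as these compounds go, it therefore sits at the limit of > 10000 nM in this assay, at which 1 of the 2 values shown sits, so its true affinity is unknown beyond that boundary. Compound 2 `COc1ccccc1-c1cc(C2CCNC2)ccc1Cl`, which carries a pyrrolidine in place of the benzylic amine, gives 400 nM in this assay. Compound 3 `CCNCc1ccc(Cl)c(-c2ccccc2OC)c1` keeps the core of compound 1 but differs by ethylamino in place of dipropylamino on a saturated chain carbon bound to an aromatic carbon. Within the data shown here, no measured step between compounds shows how such a change plays out here, and the starting value for compound 1 is itself a limit. The expected step from compound 1 to compound 3 in this assay is toward stronger binding, an at least 6.6-fold lower number from compound 1 to compound 3 (0.82 log units; beyond the scatter), though its size is uncertain. Compound 3 is expected to give about 1500 nM, within a range from 200 nM to 10000 nM.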

Compound 3, inhibition constant: 1400 nM
Compound 3: middle estimate off by 1.1-fold (0.03 log units), on the high side; the range from low to high includes it.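

In this assay, ethylamino in place of dipropylamino on the saturated chain carbon brings the open-chain amine series to a measured number, with an at least 7.1-fold lower number from compound 1 to compound 3 (0.85 log units; beyond the scatter). As far as these compounds go, compound 1 stands only as a limit, > 10000 nM, so the true size of that step stays unknown: the limit of > 10000 nM in this assay, at which 1 of the 3 values shown sits. The ethylamino compound still does not match the ring amine, with a 3.5-fold higher number from compound 2 to compound 3 (0.54 log units; beyond the scatter).

The compounds shown leave open whether a methylamino group or an unsubstituted amine on the same carbon would move the number further. They also do not separate the shorter chains from the hydrogen-bond donor that ethylamino adds, a question that diethylamino, with shortened chains and no such donor, would address.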